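A few compounds are considered here, and "the series" means these few. Any claim that something is new, unique, unknown or untested is made for them only; others in the source may bear on it.

Measured compounds:
compound 1 `O=C(CN1CCN(c2cccc(Cl)c2)CC1)N1CCN(c2nnc(-c3ccccc3)c(-c3ccccc3)n2)CC1`: 178000 nM
compound 2 `COc1ccc(N2CCN(CC(=O)N3CCN(c4nnc(-c5ccccc5)c(-c5ccccc5)n4)CC3)CC2)cc1`: limit only
compound 3 `Cc1ccc(-c2nnc(N3CCN(C(=O)CN4CCN(c5cccc(Cl)c5)CC4)CC3)nc2-c2ccc(C)cc2)cc1`: 859000 nM

Of the compounds shown here, three have been tested in an ADME assay on NIH3T3 cells (Mus musculus) for cytotoxicity, read by MTT assay, with a stated time of 24 h; a higher number here means a weaker inhibitor, a lower number a stronger inhibitor. Compound 1 gives 178000 nM. For compound 2 the result is a limit of the assay, > 910000 nM, not a number. Compound 3 gives 859000 nM.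

Compounds 1 and 2 differ in one place: 4-methoxyphenyl in place of 3-chlorophenyl on an amine nitrogen in a ring. This change made an at least 5.1-fold higher number from compound 1 to compound 2 (0.70 log units; beyond the scatter), a step that rests on (the limit of > 910000 nM in this assay, at which 1 of the 3 values shown sits).

Compound 3 carries a different core from compound 1, and the difference between the two cores is not broken down here. Compound 4 `COc1ccc(N2CCN(CC(=O)N3CCN(c4nnc(-c5ccc(C)cc5)c(-c5ccc(C)cc5)n4)CC3)CC2)cc1` is not yet measured; it stands to compound 3 as compound 2 stands to compound 1, the same change in the same place: 4-methoxyphenyl in place of 3-chlorophenyl on an amine nitrogen in a ring.

Because the earlier step of an at least 5.1-fold higher number from compound 1 to compound 2 (0.70 log units; beyond the scatter) reached the limit of this assay, the expected step for compound 4 is a 2.1-fold higher number from compound 3 to compound 4 (0.32 log units; beyond the scatter). Starting from compound 3 at 859000 nM, compound 4 is estimated at 1800000 nM, expected between 700000 nM and 5000000 nM. For compound 4 the expected outcome may well be reported only as a limit of the assay.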

Compound 4, half-maximal inhibitory concentration: 116000 nM
The estimate for compound 4 lay 16-fold (1.19 log units) above the measured number; the whole stated range lies above it.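

In this assay, putting 4-methoxyphenyl in place of 3-chlorophenyl on the core of compound 3 gave a 7.4-fold lower number from compound 3 to compound 4 (0.87 log units; beyond the scatter). On the core of compound 1 the same change moved the number the opposite way, so in this series its effect cannot simply be carried from one core to another: the same change on two cores in this assay, an at least 5.1-fold higher number (0.70 log units; beyond the scatter) from compound 1 to compound 2 and a 7.4-fold lower number (0.87 log units; beyond the scatter) from compound 3 to compound 4, at least 37-fold (1.57 log units) apart, beyond the scatter of two such steps This rests on a single pair of compounds for each core and does not show why the direction reverses, and the result for compound 2 is only a limit of the assay: the limit of > 910000 nM in this assay, at which 1 of the 4 values shown sits.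

The compounds shown leave open how other groups on that same amine nitrogen, such as a plain phenyl or a 4-chlorophenyl, would behave on each core, and so whether the reversal is special to this one pair of groups. They also leave open whether a third core, for example one with methoxy groups on its two outer phenyl rings, would follow the core of compound 1 or the core of compound 3.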